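A few compounds are considered here, and "the series" means these few. Any claim that something is new, unique, unknown or untested is made for them only; others in the source may bear on it.

Compound 3 `Fc1cccc(NC(=S)OCCc2ccccn2)c1` is one of three measured members of a small set built on a shared core. In an ADME assay on MT4 cells (Homo sapiens) for cytotoxicity, read by MTT assay (a lower number here means that less compound is tolerated, a higher number that more compound is tolerated), compound 3 gives >= 100000 nM, which is a limit of the assay rather than a number. The unsubstituted parent, compound 1 `S=C(Nc1ccccc1)OCCc1ccccn1`, also stops at a limit: in this assay compound 1 gives > 100000 nM. Compound 2 `S=C(Nc1ccccc1Cl)OCCc1ccccn1`, carrying chloro in place of hydrogen on an aromatic carbon, likewise reaches only a limit, giving > 100000 nM in this assay. Because of the limit of > 100000 nM in this assay, at which 2 of the 3 values shown sit, and (the limit of >= 100000 nM in this assay, at which 1 of the 3 values shown sits), the step that the two limits leave unreadable from compound 1 to compound 2 and the step that the two limits leave unreadable from compound 1 to compound 3 cannot be sized.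

Compound 4 `O=[N+]([O-])c1cccc(NC(=S)OCCc2ccccn2)c1` differs from compound 3 by nitro in place of fluoro on an aromatic carbon. Within the data shown here, no measured step involves a nitro group, and the two steps that exist, each swapping a halogen for hydrogen, are unreadable, so no step of known size can be drawn from them. What the three values share is that every one sits at a limit, and the likeliest outcome is that compound 4 does the same. Compound 4 is therefore expected to give about 100000 nM in this assay, with a range from 40000 nM to 300000 nM. The expected step of a number no higher from compound 3 to compound 4 (the limit leaves the size open) is essentially flat.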

Compound 4, half-maximal cytotoxic concentration: 100000 nM
The estimate for compound 4 equals the measured number at the digits printed; measured number inside the range.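

In this assay, among these compounds, compound 4 gives 100000 nM, the first plain number in this set, so nitro, meta to a large group on the aromatic ring, still leaves the compound tolerated up to a concentration this high: nitro in place of fluoro gives a number no higher from compound 3 to compound 4 (the limit leaves the size open), and nitro in place of hydrogen gives a number no higher from compound 1 to compound 4 (the limit leaves the size open). This is all the result adds, as it shows nothing of how far nitro moves the value relative to fluoro or hydrogen. The new steps to compound 4 cannot be read, because the values they start from are limits of the assay, not numbers; compound 3 stands at one limit, and compound 1 at the other: the limit of >= 100000 nM in this assay, at which 1 of the 4 values shown sits.

The compounds shown leave open whether any substituent at this place on the ring can bring the value in this assay clearly under that of compound 4, for example an amine or a carboxylic acid. They also leave open what a longer chain between the oxygen and the far ring of the shared core would do.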